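Swapping an Acetyl for a 3-Methylphenyl Ester

This account rests on a few compounds, and the source may have more. Where it says the series, first, only, none or still open, it means among the compounds named here.

Of the compounds shown here, three on one shared core have been tested in a functional assay on MCF7 cells (Homo sapiens) for antiproliferative activity, read by MTT assay, with a stated time of 48 h; a higher number here means a weaker inhibitor, a lower number a stronger inhibitor. Compound 1 `C=C1[C@H](OCC(C)C)[C@@H](OC(C)=O)[C@@H](OC(C)=O)C(C)(C)/C=C/[C@H](C)[C@H](OC(=O)c2ccccc2)[C@@]2(O)C[C@@](C)(OC(C)=O)[C@H](OC(C)=O)[C@@H]2[C@H]1OCC(C)C` reaches only a limit of the assay, > 100000 nM, which is not a number. Compound 2 `C=C1[C@H](OC(C)=O)[C@@H](OC(=O)c2cccc(C)c2)[C@@H](OC(C)=O)C(C)(C)/C=C/[C@H](C)[C@H](OC(=O)c2ccccc2)[C@@]2(O)C[C@@](C)(OC(C)=O)[C@H](OC(C)=O)[C@@H]2[C@H]1OCC(C)C` likewise gives only a limit, > 100000 nM. Among the compounds with values here, compound 3 `C=C1[C@H](OC(C)=O)[C@@H](OC(C)=O)[C@@H](OC(C)=O)C(C)(C)/C=C/[C@H](C)[C@H](OC(=O)c2ccccc2)[C@@]2(O)C[C@@](C)(OC(C)=O)[C@H](OC(C)=O)[C@@H]2[C@H]1OCC(C)C` is the sole compound with a real number, 74300 nM. The other two values sit at a limit (the limit of > 100000 nM in this assay, at which 2 of the 3 values shown sit). The steps of an at least 1.3-fold lower number from compound 1 to compound 3 (0.12 log units; that floor lies within the scatter) and an at least 1.3-fold lower number from compound 2 to compound 3 (0.12 log units; that floor lies within the scatter) both run toward compound 3, yet each floor lies within the scatter.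

Compound 4 `C=C1[C@H](OC(C)=O)[C@@H](OC(C)=O)[C@@H](OC(C)=O)C(C)(C)/C=C/[C@H](C)[C@H](OC(=O)c2ccccc2)[C@@]2(O)C[C@@](C)(OC(=O)c3cccc(C)c3)[C@H](OC(C)=O)[C@@H]2[C@H]1OCC(C)C` has not been measured. It differs from compound 3 in one place: 3-methylphenyl in place of methyl on a carbonyl carbon. The measured step of an at least 1.3-fold lower number from compound 2 to compound 3 (0.12 log units; that floor lies within the scatter) involved the same kind of aromatic ester on another oxygen and removed it; the change to compound 4 instead adds one, so the expected direction is toward a higher number, or none beyond the scatter, with a real chance of only a limit. Compound 4 is therefore expected at 110000 nM, with a range from 45000 nM to 260000 nM. That estimate corresponds to an expected step of a 1.5-fold higher number from compound 3 to compound 4 (0.17 log units; within the scatter).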

Compound 4, half-maximal inhibitory concentration: > 100000 nM
Compound 4 gave a limit, no number (the forecaster's own chance of this, stated with the estimate: 55%); the middle value lies beyond the limit too.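

In this assay, changing acetyl to (3-methylphenyl)carbonyl on this oxygen gives an at least 1.3-fold higher number from compound 3 to compound 4 (0.12 log units; that floor lies within the scatter). As far as these compounds go, compound 4 gives only a limit of the assay, not a number, so the true size of this step stays unknown and its floor does not separate it from compound 3. The new information is that the 3-methylphenyl ester now fails to yield a number on a second oxygen, as in compound 2 and compound 4, while compound 3 remains the only compound with a real number: the limit of > 100000 nM in this assay, at which 3 of the 4 values shown sit.

From the compounds shown here alone, how far compound 1, compound 2 and compound 4 lie beyond that limit remains open. Also open, going by these compounds, is whether a different group on this oxygen, such as an ester with a longer chain or one carrying an amine or a carboxylic acid, would give a number.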